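Phenyl in place of 2,2,2-trifluoroethyl on compound 3

The source may hold more compounds than are shown below. What is called first, only, known or untested is meant among the compounds shown, and "the series" means these compounds.

In a functional assay on A2780 cells (Homo sapiens) for antiproliferative activity, read by CellTiter-Glo, with a stated time of 4 days (a higher number here means a weaker inhibitor, a lower number a stronger inhibitor), compound 1 `O=C(NCc1cccnc1)Nc1ccc(CN2C(=O)c3ccccc3C2=O)cc1` gives 100 nM. Compound 2 `O=C(CCc1cccnc1)Nc1ccc(CN2C(=O)c3ccccc3C2=O)cc1` reports only a limit, > 10000 nM. For the measured compounds named here, the one measured step, an at least 100-fold higher number from compound 1 to compound 2 (2.00 log units; beyond the scatter), is large, but it puts 2-(pyridin-3-yl)ethyl in place of ((pyridin-3-yl)methyl)amino, so it does not touch the group changed here. Compound 3 `C[C@H](NC(=O)CC(F)(F)F)c1ccc(NC(=O)[C@H]2C[C@@H]2c2cccnc2)cc1` gives 5 nM, the lowest number shown and beyond the scatter from compound 1. Compound 4 `C[C@H](NC(=O)c1ccccc1)c1ccc(NC(=O)[C@H]2C[C@@H]2c2cccnc2)cc1` carries phenyl in place of 2,2,2-trifluoroethyl on a carbonyl carbon. Going by the values given here, no measured step changes this group, so the size of the change stays open and only a modest rise is expected. The expected step is a 1.6-fold higher number from compound 3 to compound 4 (0.20 log units; within the scatter), which would stay within the scatter. For compound 4 the estimated value is 8 nM, with a range of 2 nM to 40 nM.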

Compound 4, half-maximal inhibitory concentration: 1 nM
Compound 4: the middle estimate sits 8.0-fold (0.90 log units) above what was measured; the measured number lies below the stated range.
By their numbers in this assay, from the lowest: compound 4; then compound 3; then compound 1. At a limit, above all of these: compound 2.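

In this assay the carbonyl carbon that carries the amide-type nitrogen takes phenyl in place of 2,2,2-trifluoroethyl, and the step is a 5.0-fold lower number from compound 3 to compound 4 (0.70 log units; beyond the scatter) in the stronger direction. The earlier compounds shown here held no change at this group, and this one shows that a six-membered aromatic ring of carbon only is accepted here with a gain. The data shown give no reason for this step.

Open, as far as these compounds go, is whether an amine, a carboxylic acid or a longer chain would be accepted here as phenyl is. Also open, from the compounds shown here alone, is whether phenyl with a chlorine or methoxy group on it would hold this gain.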